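Fluoro to chloro on the weakly cytotoxic dichloroacetamides

A few compounds are considered here, and "the series" means these few. Any claim that something is new, unique, unknown or untested is made for them only; others in the source may bear on it.

In a functional assay on KB 3-1 cells (Homo sapiens) for cytotoxicity, read by MTT assay, with a stated time of 68 h (a higher number here means a weaker inhibitor, a lower number a stronger inhibitor), compound 1 (`COc1cccc(-c2cccc(NC(=O)C(Cl)Cl)c2)c1`) gives 43300 nM and compound 2 (`O=C(Nc1cccc(-c2ccccc2F)c1)C(Cl)Cl`) gives 48300 nM. These two values lie within the scatter of each other, so compound 2 stands with compound 1 and no order can be drawn between them. Compound 3 (`O=C(Nc1cccc(-c2cccc(Cl)c2)c1)C(Cl)Cl`) gives > 50000 nM, which is a limit of the assay and not a number.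

The next change leads to compound 4 (`O=C(Nc1cccc(-c2ccccc2Cl)c1)C(Cl)Cl`): chloro in place of fluoro on an aromatic carbon. In words, this is chloro in place of fluoro on an aromatic carbon, ortho to a large group.

Going by the values given here, only one measured step bears on it, an at least 1.1-fold higher number from compound 1 to compound 3 (0.06 log units; that floor lies within the scatter). That step also brings in chloro on an aromatic carbon, but methoxy leaves there rather than fluoro, so it is indirect evidence. It gives only a floor and shows no change beyond the scatter.

No shift beyond the scatter is therefore expected in this assay, in either direction. The estimated 1.1-fold lower number from compound 2 to compound 4 (0.03 log units; within the scatter) reflects this. A report of compound 4 only as a limit would be no surprise, given (the limit of > 50000 nM in this assay, at which 1 of the 3 values shown sits). For compound 4 the expected value is 45000 nM, with an estimated range from 25000 nM to 60000 nM.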

Compound 4, half-maximal inhibitory concentration: > 50000 nM
Compound 4 was reported as a limit; the forecaster's own chance of this, stated with the estimate: 45%; at least 1.1-fold (0.04 log units) between middle value and limit.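

Chloro in place of fluoro on an aromatic carbon, ortho to a large group, now has a direct reading in this assay: an at least 1.0-fold higher number from compound 2 to compound 4 (0.01 log units; that floor lies within the scatter), whereas the earlier compounds offered only an indirect step with methoxy leaving. For compound 4, > 50000 nM is a limit of the assay and not a number, so the step gives only a floor, and no change beyond the scatter can be read from it. The limit is also no longer a single case in this small set, with chloro on the aromatic ring in both compounds that reach it: the limit of > 50000 nM in this assay, at which 2 of the 4 values shown sit.

From the compounds shown here alone, whether chloro at this position changes the cytotoxicity read-out at all remains open, and compound 4 sets no value that would settle it. Also open, going by these compounds, is what an amine or a carboxylic acid would do on this aromatic carbon, and whether any such group would give a number clearly stronger than those of compound 1 and compound 2.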